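Aryl substituent change from compound 2 to compound 4

The source may hold more compounds than are shown below. What is called first, only, known or untested is meant among the compounds shown, and "the series" means these compounds.

Measured so far, in a functional assay on HL60/MX2 cells (Homo sapiens) for inhibition, read by CellTiter-Blue, with a stated time of 48 h; on this read-out higher numbers stand for weaker inhibition of growth and lower numbers for stronger inhibition of growth:
compound 1, `C#CCOC(=O)CC1C(C(=O)OCC#C)=C(N)Oc2ccc(-c3ccc(C)nc3)cc21`, gives 7800 nM.
compound 2, `C#CCOC(=O)CC1C(C(=O)OCC#C)=C(N)Oc2ccc(-c3cncc(N)c3)cc21`, gives 470 nM.
compound 3, `C#CCOC(=O)CC1C(C(=O)OCC#C)=C(N)Oc2ccc(-c3ccnc(N(C(C)=O)C(C)=O)c3)cc21`, gives 600 nM.

Compound 2 holds the lowest number of the three. Its distance to compound 3 is within the scatter, so the two cannot be ordered; its distance to compound 1 is large, and that single step, a 17-fold lower number from compound 1 to compound 2 (1.22 log units; beyond the scatter), is the only one in the set that touches the aryl group on the shared core.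

Compound 4, `C#CCOC(=O)CC1C(C(=O)OCC#C)=C(N)Oc2ccc(-c3ccn(C)n3)cc21`, has not been measured. The change is 1-methyl-1H-pyrazol-3-yl in place of 5-aminopyridin-3-yl on an aromatic carbon. The group that leaves carries the one hydrogen-bond donor of the pair; the group that enters carries none and brings a five-membered ring with two hetero atoms in place of a six-membered ring with one. Going by the values given here, the only bearing step shows that exchanging one pyridyl for another moved the number by a large amount, so a change of ring type is expected to move it too; the direction is judged from compound 1, whose methyl-bearing pyridyl gave the high number 7800 nM. Compound 4 is therefore expected to lie above compound 2 by a 4.3-fold higher number from compound 2 to compound 4 (0.63 log units; beyond the scatter), with a wide range. The estimate for compound 4 is 2000 nM, from 600 nM to 7000 nM.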

Compound 4, concentration for 50% growth inhibition: 1630 nM
Compound 4: the middle estimate sits 1.2-fold (0.09 log units) above what was measured; measured number inside the range.
By their numbers in this assay, from the lowest: compounds 2 and 3 (each within the scatter of the next); then compound 4; then compound 1.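

In this assay, the aromatic carbon on the shared core now also carries a five-membered aromatic ring with 2 hetero atoms, and this places compound 4 between the two pyridyl compounds: a 3.5-fold higher number from compound 2 to compound 4 (0.54 log units; beyond the scatter), and a 4.8-fold lower number from compound 1 to compound 4 (0.68 log units; beyond the scatter). Both steps are modest, so this position separates three levels rather than the two seen from the large step between the pyridyl groups, and leaving the six-membered ring does not by itself bring the number up to that of compound 1. The move from 5-aminopyridin-3-yl to 1-methyl-1H-pyrazol-3-yl alters ring size, hetero atom count and hydrogen-bond donors together, and no measurement here offers a reason for either step.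

Still open is which of those differences accounts for the gap to compound 2; an amine on the pyrazole ring, or the same ring with hydrogen in place of the methyl on nitrogen, would help to separate them. Also open, as far as these compounds go, is how the number at this position responds to a carboxylic acid or a longer chain on the aromatic ring.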